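The source may report more compounds than this note shows. Statements on the series, on what has been measured and on what is new or still open speak of the compounds shown alone.

Working notes on the series built on the shared core of compound 1 (`O=C1C=CC2(C=C1)OCC(Cc1ccc(F)cc1)C(=O)N2c1ccccc1`), read in a functional assay on BV-2 cells (Mus musculus), read by Griess assay, with a stated time of 24 h; on this read-out lower numbers stand for stronger inhibition and higher numbers for weaker inhibition. Compound 1 gives 400 nM and compound 2 (`O=C1C=CC2(C=C1)OCC(Cc1ccc(Cl)cc1)C(=O)N2c1ccccc1`) gives 540 nM. Compound 3 (`O=C1C=CC2(C=C1)OCC(Cc1ccc(Br)cc1)C(=O)N2c1ccccc1`) gives 1380 nM, the highest number of the three. Compound 4 (`O=C1C=CC2(C=C1)OCC(Cc1ccc([N+](=O)[O-])cc1)C(=O)N2c1ccccc1`) carries nitro in place of bromo on an aromatic carbon. Three measured swaps at the same place bear on this change: a 1.4-fold higher number from compound 1 to compound 2 (0.13 log units; within the scatter), a 2.6-fold higher number from compound 2 to compound 3 (0.41 log units; beyond the scatter) and a 3.5-fold higher number from compound 1 to compound 3 (0.54 log units; beyond the scatter). The first lies within the scatter and the other two are modest. None involves nitro, so only a modest step or none beyond the scatter is expected, leaning towards a lower number. The expected step is a 1.5-fold lower number from compound 3 to compound 4 (0.19 log units; within the scatter). For compound 4 the estimate is 900 nM, with an expected range of 350 nM to 2300 nM.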

Compound 4, half-maximal inhibitory concentration: 430 nM
Estimate against measurement, compound 4: 2.1-fold (0.32 log units) above; the measured number falls inside the stated range.
By their numbers in this assay, from the lowest: compounds 1, 4 and 2 (each within the scatter of the next); then compound 3.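

At this position nitro takes the series back from the bromo result, with a 3.2-fold lower number from compound 3 to compound 4 (0.51 log units; beyond the scatter), while a 1.3-fold lower number from compound 2 to compound 4 (0.10 log units; within the scatter) and a 1.1-fold higher number from compound 1 to compound 4 (0.03 log units; within the scatter) leave compound 4 indistinguishable from compound 2 and compound 1. The rise seen on going to bromo therefore does not carry over to a larger group by heavy-atom count, and compound 3 alone stands apart as the weakest of the four. Nothing available explains why bromo and nitro differ here.

Still open, as far as these compounds go, is how an amine, a carboxylic acid or a longer chain would read at this position.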